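This account rests on a few compounds, and the source may have more. Where it says the series, first, only, none or still open, it means among the compounds named here.

Of the compounds shown here, three have so far been measured in a functional assay on T47D cells (Homo sapiens) for activation; on this read-out higher numbers stand for an effect only at larger amounts of compound and lower numbers for an effect already at smaller amounts. Compound 1 `COc1ccc2c(c1)OC(N)=C(C#N)C2c1ccccc1` gives 360000000 nM. Compound 2 `COc1cc(C2C(C#N)=C(N)Oc3c2ccc(N)c3N)cc(I)c1OC` gives 49000000 nM. Compound 3 `COc1ccc2c(c1)OC(N)=C(C#N)C2c1cccc(Br)c1` gives 52000000 nM, the second highest of the three numbers; compound 2 sits closest to it, the two lying within the scatter of each other, while compound 1 stands further off. Within the data shown here, the only step known between two compounds that differ in a single place is a 6.9-fold lower number from compound 1 to compound 3 (0.84 log units; beyond the scatter), a modest change that came with bromo in place of hydrogen on an aromatic carbon.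

Compound 4 `COc1ccc2c(c1)OC(N)=C(C#N)C2c1cccc(Cl)c1` remains to be measured. It differs from compound 3 by chloro in place of bromo on an aromatic carbon. Among the measured compounds shown here, no measured pair shows one halogen swapped for another, so the known step bears on this change only loosely, and one halogen replacing another is a far smaller alteration than a halogen replacing hydrogen. The expected step is therefore a 1.3-fold higher number from compound 3 to compound 4 (0.13 log units; within the scatter), a shift not expected to go beyond the usual scatter. For compound 4 the estimate is 70000000 nM, with a range from 30000000 nM to 200000000 nM.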

Compound 4, half-maximal effective concentration: 80000000 nM
Beside the measured number, compound 4's estimate is 1.1-fold (0.06 log units) below it; low and high end bracket the measured number.
By their numbers in this assay, from the lowest: compounds 2, 3 and 4 (each within the scatter of the next); then compound 1.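

Replacing 3-bromophenyl with 3-chlorophenyl gives a 1.5-fold higher number from compound 3 to compound 4 (0.19 log units; within the scatter), so on this read-out the two halogens cannot be told apart at this place on the aromatic ring. Chloro, like bromo, stands clear of hydrogen there: the new comparison shows a 4.5-fold lower number from compound 1 to compound 4 (0.65 log units; beyond the scatter), alongside the earlier 6.9-fold lower number from compound 1 to compound 3 (0.84 log units; beyond the scatter), so the effect is not tied to bromo alone, although this pattern rests only on compound 3 and compound 4. No supporting data are available to explain this result.

Going by these compounds, it remains open whether fluoro, an amine or a carboxylic acid at this place would also go with a lower number than hydrogen. It is also unknown whether chloro or bromo would have the same effect elsewhere on this ring.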